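The source may report more compounds than this note shows. Statements on the series, on what has been measured and on what is new or still open speak of the compounds shown alone.

Two compounds measured in a functional assay on FM3A cells (Mus musculus) for inhibition, read by cell counting, with a stated time of 2 days (a lower number here means a stronger inhibitor, a higher number a weaker inhibitor), frame this step. Compound 1, with structure `C=C(Br)C(=O)Nc1cccc(-c2cn3nc(-c4ccccc4)sc3n2)c1`, gives 900 nM. Compound 2, with structure `COc1ccc(Cc2nn3cc(-c4cccc(N)c4)nc3s2)cc1`, gives 100000 nM. Compound 2 therefore stands at the highest number of the two, and the gap to compound 1 is beyond the usual scatter of this assay, so compound 2 is the clearly weaker inhibitor of the pair.

Compound 3, with structure `C=C(Br)C(=O)Nc1cccc(-c2cn3nc(Cc4ccc(OC)cc4)sc3n2)c1`, has not yet been measured. It differs from compound 2 in one place: (1-bromoethenyl)carbonyl in place of hydrogen on a nitrogen on an aromatic ring. The group that enters is the same (1-bromoethenyl)carbonyl group that compound 1 already carries on its ring nitrogen, while the rest of compound 3 stays as in compound 2.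

Among the compounds with values here, no direct step between two measured compounds isolates this change, so the expectation rests on the two values alone. Because compound 1 reaches 900 nM with this group present, the change from compound 2 to compound 3 is expected to lower the number by a large step, a 33-fold lower number from compound 2 to compound 3 (1.52 log units; beyond the scatter). Compound 3 is thus estimated at 3000 nM in this assay, with a plausible range from 500 nM to 30000 nM.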

Compound 3, half-maximal inhibitory concentration: 850 nM
Estimate against measurement, compound 3: 3.5-fold (0.55 log units) above; low and high end bracket the measured number.
By their numbers in this assay, from the lowest: compounds 3 and 1 (each within the scatter of the next); then compound 2.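

In this assay, within the data shown here, (1-bromoethenyl)carbonyl in place of hydrogen on a nitrogen on an aromatic ring gives a 120-fold lower number from compound 2 to compound 3 (2.07 log units; beyond the scatter) and so supplies the first direct reading of this change, which the earlier compounds showed only as two values from different molecules. A second comparison, 4-methoxybenzyl in place of phenyl on an aromatic carbon, gives a 1.1-fold lower number from compound 1 to compound 3 (0.02 log units; within the scatter) and shows that, with the (1-bromoethenyl)carbonyl group in place, these two groups cannot be told apart in this assay. Why the change from amino to ((1-bromoethenyl)carbonyl)amino counts for so much remains unexplained, with nothing available here that bears on the cause.

The compounds shown leave open whether the whole group or the bromine in particular goes with this step, a question that a plain acetyl group on the same nitrogen, or chlorine in place of the bromine, could address. They also leave open how far the aromatic carbon accepts other groups, with only phenyl and 4-methoxybenzyl compared there and nothing such as a methyl group or a carboxylic acid among the compounds.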